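The compounds below may be only part of what the source reports. "The series", "measured", "known", "first", "only" and "open" are said of these compounds alone.

Compound 1 `CC(=O)CC/C=C(\C)CCC1=C(C)CCCC1(C)C`: in a functional assay on UACC-257 cells (Homo sapiens) for inhibition (a lower number here means a stronger inhibitor of growth, a higher number a weaker inhibitor of growth), compound 1 gives > 15000 nM, which is a limit of the assay and not a number.
Compound 2 `C=C1CCC[C@H]2[C@](C)(CC[C@]3(C)CC[C@@H]([C@@H](C)C(=O)O)OO3)[C@@H](C)CC[C@]12C`: compound 2 gives > 5000 nM, also a limit.
Compound 3 `C=C1CCCC(C)(C)C1CC[C@@]1(C)CC[C@H]([C@@H](C)C(=O)O)OO1`: compound 3 gives > 12500 nM, again a limit.

Compound 2 thus stands only at a limit in this assay, as do the other two measured compounds, so no exact number is known for any of them. Compound 4 `C=C1CCC[C@H]2[C@](C)(CC[C@]3(C)CC[C@H]([C@@H](C)C(=O)O)OO3)[C@@H](C)CC[C@]12C` keeps every atom and bond of compound 2 and differs in a single point: the two compounds have the same atoms and bonds and differ only in configuration as drawn: 1 of 7 stereo elements differ; a stereocentre at a saturated ring carbon is drawn S in compound 2 and R in compound 4. Going by the values given here, no measured step between compounds exists here, so the size of such a change cannot be read from the data. A change of configuration at one ring carbon is expected to shift this assay by no more than the usual scatter, if at all. Compound 4 is therefore estimated at about 7000 nM, with a range from 3000 nM to 20000 nM. The expected step is a step that the limit leaves unreadable from compound 2 to compound 4.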

Compound 4, concentration for 50% growth inhibition: 3680 nM
Compound 4: middle estimate off by 1.9-fold (0.28 log units), on the high side; measured number inside the range.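

In this assay, going by these compounds alone, compound 4 is the first compound here with an exact number rather than a limit, and it differs from compound 2 only at one saturated ring carbon, drawn S in compound 2 and R in compound 4. Changing that single centre gives an at least 1.3-fold lower number from compound 2 to compound 4 (0.13 log units; that floor lies within the scatter), so this floor alone does not show that the configuration matters. Compound 2 gives > 5000 nM, which is a limit.

On these data alone, the true size of the step stays open, with no exact number for compound 2. Also open, as far as these compounds go, is how an amide or a methyl ester in place of the carboxylic acid would behave at this centre.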